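Compound 2 to compound 4: a smaller amine substituent

A few compounds are considered here, and "the series" means these few. Any claim that something is new, unique, unknown or untested is made for them only; others in the source may bear on it.

In a functional assay on HCT-15 cells (Homo sapiens) for inhibition, read by MTT assay, with a stated time of 72 h (on this read-out higher numbers stand for weaker inhibition and lower numbers for stronger inhibition), compound 2 (`COc1cc(Oc2cccc(Nc3ccccc3)c2)cc(OC)c1CN[C@H](C)c1ccccc1`) gives 7550 nM as its value. On the same read-out compound 1 (`COc1cc(Oc2cccc(Nc3ccccc3)c2)cc(OC)c1CNCc1ccc(C)cc1`) gives 5400 nM and compound 3 (`COc1ccc([C@@H](C)NCc2c(OC)cc(Oc3cccc(Nc4ccccc4)c3)c(OC)c2OC)cc1`) gives 4690 nM as theirs. Compound 2 lies within the scatter of both, so these three compounds cannot be told apart here.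

Compound 4 (`COc1cc(Oc2cccc(Nc3ccccc3)c2)cc(OC)c1CN(C)C`) differs from compound 2 at the amine on a saturated chain carbon bound to an aromatic carbon. The change is dimethylamino in place of (1-phenylethyl)amino on a saturated chain carbon bound to an aromatic carbon and it takes away the six-membered aromatic ring and the defined stereocentre together.

Among the measured compounds shown here, the one measured step bearing on this is a 1.4-fold higher number from compound 1 to compound 2 (0.15 log units; within the scatter) with 1-phenylethyl in place of 4-methylbenzyl on an amine nitrogen. That step exchanges one ring-bearing group for another. For the measured compounds named here, none of the measured compounds lacks an aromatic ring on the amine, so the loss of that ring is untested and the expectation is uncertain. A moderate move towards a higher number, meaning weaker inhibition, is expected, and the estimated change is a 1.3-fold higher number from compound 2 to compound 4 (0.12 log units; within the scatter) in this assay with wide uncertainty. For compound 4 the estimated value is 10000 nM with 3500 nM to 30000 nM as the expected range.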

Compound 4, half-maximal inhibitory concentration: 15600 nM
Compound 4: middle estimate off by 1.6-fold (0.19 log units), on the low side, and the stated range covers the measured number.
By their numbers in this assay, from the lowest: compounds 3, 1 and 2 (each within the scatter of the next); then compound 4.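

Earlier, exchanging one ring-bearing group for another on the amine stayed within the scatter, but replacing such a group with dimethylamino at this saturated chain carbon bound to an aromatic carbon does not: this assay shows a 2.1-fold higher number from compound 2 to compound 4 (0.32 log units; beyond the scatter) and a 2.9-fold higher number from compound 1 to compound 4 (0.46 log units; beyond the scatter) in the second comparison. Both steps are modest, yet they show that the number responds to the amine substituent at this place, with weaker inhibition for dimethylamino than for either ring-bearing amine it can be compared with in one place. Compound 1 carries no defined stereocentre, so the step to dimethylamino does not depend on losing one, and no measurement available here explains the shift.

The change from (1-phenylethyl)amino or (4-methylbenzyl)amino to dimethylamino removes the aromatic ring, the amine hydrogen and much of the substituent's size together, so the compounds shown do not separate these contributions. From the compounds shown here alone, a methylamino group would keep the amine hydrogen without the ring, while an N-methylbenzylamino group would keep the ring without that hydrogen, and how either would read on this assay remains open.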